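This account rests on a few compounds, and the source may have more. Where it says the series, first, only, none or still open, it means among the compounds named here.

Compound 1, `C[C@H](CCCOc1ccccc1CN(C)C(=O)c1ccc(-c2ccco2)cc1)CC(=O)O`, in an ADME assay on the whole organism (strain CD-1) for pharmacokinetics, with Mus musculus as the target, at a dose of 3 mg/kg by the intravenous route (on this read-out higher numbers stand for higher exposure at the dose given and lower numbers for lower exposure), gives 77700 ng.h/mL.
Compound 2, `C[C@@H](CCCOc1ccccc1CN(C)C(=O)c1ccc(-c2ccco2)cc1)CC(=O)O`, gives 30800 ng.h/mL.
Compound 3, `C/C(=C\CCCOc1ccccc1CN(C)C(=O)c1ccc(-c2ccco2)cc1)C(=O)O`, gives 1300 ng.h/mL.

Compound 2 stands second highest of the three numbers. Its nearest neighbour is compound 1: a 2.5-fold lower number from compound 1 to compound 2 (0.40 log units; beyond the scatter), a modest step resting on (the fact that compounds 1 and 2 differ only in the configuration as drawn). Compound 3 lies furthest away: a 24-fold lower number from compound 2 to compound 3 (1.37 log units; beyond the scatter).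

Compound 4, `C/C(=C\C(=O)O)CCCOc1ccccc1CN(C)C(=O)c1ccc(-c2ccco2)cc1`, has not yet been measured in this assay. It differs from compound 2 in one place: 2-carboxy-1-methylethenyl in place of 1-(carboxymethyl)ethyl on a saturated chain carbon, three bonds along the chain from an oxygen on an aromatic ring. The measured steps that bear on this change are those in which 1-(carboxymethyl)ethyl gives way to 2-carboxyprop-1-en-1-yl, namely a 60-fold lower number from compound 1 to compound 3 (1.78 log units; beyond the scatter) and a 24-fold lower number from compound 2 to compound 3 (1.37 log units; beyond the scatter), both large drops. The group entering compound 4, 2-carboxy-1-methylethenyl, is the same size and likewise carries a double bond into the chain, so a large decrease is expected: a 15-fold lower number from compound 2 to compound 4 (1.19 log units; beyond the scatter). Compound 4 is therefore estimated to give 2000 ng.h/mL, within a range from 500 ng.h/mL to 8000 ng.h/mL.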

Compound 4, area under the concentration-time curve: 4700 ng.h/mL
Estimate against measurement, compound 4: 2.4-fold (0.37 log units) below; measured number inside the range.
By their numbers in this assay, from the lowest: compound 3; then compound 4; then compound 2; then compound 1.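

The double bond lowers the number against both saturated compounds, with a 6.6-fold lower number from compound 2 to compound 4 (0.82 log units; beyond the scatter) and a 17-fold lower number from compound 1 to compound 4 (1.22 log units; beyond the scatter), so the loss seen with compound 3 is not confined to one unsaturated arrangement. Its size does depend on the arrangement, however: with the same count of heavy atoms in the group, there is a 3.6-fold higher number from compound 3 to compound 4 (0.56 log units; beyond the scatter). Where the double bond and the methyl sit along the chain therefore matters in this assay, although neither unsaturated compound comes close to compound 1 or compound 2.

On these data alone, whether a cyclopropyl ring in place of the double bond, or a tetrazole in place of the carboxylic acid, would retain the higher numbers remains open. Nothing given here bears on why the two unsaturated arrangements differ.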